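Aryl halogen shift on the biphenyl amide: compound 4

A few compounds are considered here, and "the series" means these few. Any claim that something is new, unique, unknown or untested is made for them only; others in the source may bear on it.

Three compounds carry the shared core with a biphenyl amide tail. In an assay on CHO-K1 cells for displacement of a labelled ligand from 5-hydroxytryptamine receptor 7 (Homo sapiens), read by scintillation counting (on this read-out lower numbers stand for stronger inhibition and higher numbers for weaker inhibition), compound 1 `COc1ccccc1N1CCN(CCCC(=O)NCc2ccccc2-c2ccccc2)CC1` gives 64.5 nM, compound 2 `COc1ccccc1N1CCN(CCCCC(=O)NCc2ccccc2-c2ccccc2F)CC1` gives 36.5 nM, and compound 3 `COc1ccccc1N1CCN(CCC(=O)NCc2ccccc2-c2ccccc2)CC1` gives 187 nM. Compound 2 shows the lowest number of the three, but compound 1 sits within the usual scatter of it; only compound 3 lies beyond that scatter.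

Compound 4 `COc1ccccc1N1CCN(CCCCC(=O)NCc2ccccc2-c2cccc(Cl)c2)CC1` differs from compound 2 by 3-chlorophenyl in place of 2-fluorophenyl on an aromatic carbon. Among the measured compounds shown here, no measured pair in this set isolates such a change, so no step is known for it. In this assay the expected step of a 1.2-fold higher number from compound 2 to compound 4 (0.09 log units; within the scatter) is small, probably not beyond the scatter, in either direction. Compound 4 is therefore estimated at 45 nM, with a range from 18 nM to 115 nM.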

Compound 4, inhibition constant: 405 nM
The estimate for compound 4 lay 9.0-fold (0.95 log units) below the measured number, outside the stated range (above it).
By their numbers in this assay, from the lowest: compounds 2 and 1 (each within the scatter of the next); then compound 3; then compound 4.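

In this assay, this aromatic position proves highly sensitive: 3-chlorophenyl in place of 2-fluorophenyl gives an 11-fold higher number from compound 2 to compound 4 (1.05 log units; beyond the scatter), although the two groups have the same heavy-atom count and neither has hydrogen-bond donors or acceptors. The earlier compounds shown here gave no reading of any change at this position. Nothing available accounts for the size of this step.

Fluorine gives way to chlorine and the halogen shifts in the same step, so the contribution of each stays open. As far as these compounds go, how unsubstituted phenyl or a nitrile-bearing phenyl would read on the chain of compound 2 also stays open.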